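The source may hold more compounds than are shown below. What is called first, only, known or untested is meant among the compounds shown, and "the series" means these compounds.

Compounds measured so far:
- compound 1 `Cc1cccc(-c2noc(C3CN(S(=O)(=O)c4cccc(C)c4)C3)n2)c1`: 650 nM
- compound 2 `Cc1cccc(S(=O)(=O)N2CC(c3nc(-c4cccc(Cl)c4)no3)C2)c1`: 390 nM
- compound 3 `O=C(C1CCCO1)N1CC(c2nc(-c3cccc(Cl)c3)no2)C1`: 890 nM

All three were tested in an assay on HEK293 cells for negative allosteric modulation of metabotropic glutamate receptor 5 (Homo sapiens), read by FLIPR; on this read-out higher numbers stand for weaker inhibition and lower numbers for stronger inhibition. Compound 2 gives the lowest of the three numbers there. For the measured compounds named here, the only single-point step among the measured compounds runs from compound 1 to compound 2, a 1.7-fold lower number from compound 1 to compound 2 (0.22 log units; within the scatter), so these two cannot be told apart with confidence. Compound 3, with its different group on the ring nitrogen, gives a number beyond the scatter from compound 2 in this assay.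

Compound 4 `O=S(=O)(c1ccc(F)cc1)N1CC(c2nc(-c3cccc(Cl)c3)no2)C1` differs from compound 2 in one place: 4-fluorophenyl in place of 3-methylphenyl on a sulfonyl sulfur. Going by the values given here, no measured pair changes the aromatic ring on the sulfonyl sulfur, so no step from the data bears directly on this change; the step from compound 1 to compound 2 concerns a different ring. With nothing pointing either way, the expectation is that the number stays close to that of compound 2, with no step beyond the scatter in this assay. The estimated step from compound 2 to compound 4 is therefore small, a 1.2-fold higher number from compound 2 to compound 4 (0.06 log units; within the scatter). For compound 4 the expected value in this assay is 450 nM, with a range from 150 nM to 1400 nM.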

Compound 4, half-maximal inhibitory concentration: 130 nM
Beside the measured number, compound 4's estimate is 3.5-fold (0.54 log units) above it; measured number outside the range, below it.
By their numbers in this assay, from the lowest: compound 4; then compounds 2, 1 and 3 (each within the scatter of the next, the first and the last beyond it).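

Replacing 3-methylphenyl with 4-fluorophenyl on a sulfonyl sulfur gives a 3.0-fold lower number from compound 2 to compound 4 (0.48 log units; beyond the scatter) in this assay. For the compounds shown here, the earlier single-point step, a 1.7-fold lower number from compound 1 to compound 2 (0.22 log units; within the scatter), concerned a different ring and stayed within the scatter, so this is the first sign that a change can move the number clearly, and the aromatic ring on the sulfonyl sulfur is where it happens. The two groups match in heavy-atom count, ring type, hydrogen-bond donors and acceptors, and net charge, so those counts do not separate them, and nothing available here explains the step.

This single swap removes the methyl and adds the fluorine while also changing where the substituent sits on the ring, so the compounds shown cannot say which of these matters; a plain phenyl, a 3-fluorophenyl or a 4-methylphenyl on the sulfonyl sulfur would help pull them apart. Going by these compounds, it also stays open whether the 4-fluorophenyl would give a similar step when the other ring carries methyl, as in compound 1, rather than chloro.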